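The compounds below may be only part of what the source reports. "The series", "measured", "known", "first", "only" and "open" are said of these compounds alone.

In a functional assay on MGC-803 cells (Homo sapiens) for antiproliferative activity, read by MTT assay, with a stated time of 48 h (a higher number here means a weaker inhibitor, a lower number a stronger inhibitor), the measured compounds stand as follows:

compound 1 `COc1ccc(NC(=O)Nc2cccc(CNc3nccnc3Cl)c2)cc1`: 9240 nM
compound 2 `COc1ccccc1NC(=O)Nc1cccc(CNc2nccnc2Cl)c1`: 12200 nM
compound 3 `Cc1ccc(NC(=O)Nc2cccc(CNc3nccnc3Cl)c2)c(C)c1`: 10100 nM

Compound 1 carries the lowest of the three numbers, yet the steps of a 1.3-fold higher number from compound 1 to compound 2 (0.12 log units; within the scatter) and a 1.1-fold higher number from compound 1 to compound 3 (0.04 log units; within the scatter) both lie within the scatter, as does a 1.2-fold lower number from compound 2 to compound 3 (0.08 log units; within the scatter); no order among the three can be read from these values.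

Compound 4 `O=C(Nc1cccc(CNc2nccnc2Cl)c1)Nc1ccc(Cl)cc1Cl` is reached from compound 1 by 2,4-dichlorophenyl in place of 4-methoxyphenyl on an amide-type nitrogen. Among the compounds with values here, none of the measured steps exchanges the 4-methoxyphenyl for a halogen-bearing ring, so the bearing is indirect: every exchange of the aryl group on the amide-type nitrogen recorded so far left this assay unchanged within the scatter. The expectation is therefore no step beyond the scatter for compound 4 in this assay.

Compound 4 is estimated at 9000 nM, with a range of 3500 nM to 25000 nM, which is expected to amount to a 1.0-fold lower number from compound 1 to compound 4 (0.01 log units; within the scatter).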

Compound 4, half-maximal inhibitory concentration: 6430 nM
Compound 4: the middle estimate sits 1.4-fold (0.15 log units) above what was measured, within the range that was stated.
By their numbers in this assay, from the lowest: compounds 4, 1, 3 and 2 (each within the scatter of the next).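

In this assay, a halogen-bearing ring on the amide-type nitrogen now stands within the scatter of all three earlier aryl groups, with a 1.4-fold lower number from compound 1 to compound 4 (0.16 log units; within the scatter) and a 1.6-fold lower number from compound 3 to compound 4 (0.20 log units; within the scatter) and a 1.9-fold lower number from compound 2 to compound 4 (0.28 log units; within the scatter). Across these four compounds, the position therefore tolerates 2,4-dichlorophenyl as well as the methoxyphenyl and dimethylphenyl groups, with no order among them. No supporting measurement bears on this flat result.

Open, from the compounds shown here alone, is whether a phenyl ring carrying an amine or a carboxylic acid would give a step beyond the scatter. The same applies to a longer chain on this nitrogen in place of the ring.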